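The compounds below may be only part of what the source reports. "The series", "measured", "known", "first", "only" and "open" are said of these compounds alone.

Measured in a functional assay on A549 cells (Homo sapiens) for inhibition, read by MTT assay, with a stated time of 48 h; a higher number here means a weaker inhibitor, a lower number a stronger inhibitor:
- compound 1 `Cc1ccc(NC(=O)Nc2cccc(-c3cccc4[nH]nc(N)c34)c2)cc1`: 1660 nM
- compound 2 `Nc1n[nH]c2cccc(-c3cccc(NC(=O)Nc4nccs4)c3)c12`: > 500000 nM (a limit, not a number)

Compound 2 has only a limit in this assay: the limit of > 500000 nM in this assay, at which 1 of the 2 values shown sits. Compound 3 `Nc1n[nH]c2cccc(-c3cccc(NC(=O)Nc4ccccc4F)c3)c12` carries 2-fluorophenyl in place of 1,3-thiazol-2-yl on an amide-type nitrogen. For the measured compounds named here, one measured step bears on this change, an at least 300-fold higher number from compound 1 to compound 2 (2.47 log units; beyond the scatter), where 1,3-thiazol-2-yl replaced 4-methylphenyl. Compound 3 reverses that exchange in part, restoring a substituted phenyl, though with a different substituent. The expected step, a large one towards a lower number in this assay, is an at least 160-fold lower number from compound 2 to compound 3 (2.22 log units; beyond the scatter). For compound 3 the estimated value is 3000 nM, with an expected range of 700 nM to 20000 nM.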

Compound 3, half-maximal inhibitory concentration: 1170 nM
Estimate against measurement, compound 3: 2.6-fold (0.41 log units) above, within the range that was stated.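

In this assay, the two substituted phenyl groups on the amide-type nitrogen are not told apart, with a 1.4-fold lower number from compound 1 to compound 3 (0.15 log units; within the scatter). Exchanging 1,3-thiazol-2-yl for 2-fluorophenyl gives an at least 420-fold lower number from compound 2 to compound 3 (2.63 log units; beyond the scatter), so a substituted phenyl other than 4-methylphenyl also carries the activity. Compound 2 has a limit, not a number: the limit of > 500000 nM in this assay, at which 1 of the 3 values shown sits.

On these data alone, whether unsubstituted phenyl or cyclohexyl on this nitrogen would keep the value remains open. Also open, as far as these compounds go, is whether an oxazol-2-yl or pyridin-2-yl group would share the weak result of 1,3-thiazol-2-yl.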